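A few compounds are considered here, and "the series" means these few. Any claim that something is new, unique, unknown or untested is made for them only; others in the source may bear on it.

Within the data shown here, only two members have been tested so far in a functional assay on MDA-MB-231 cells (Homo sapiens) for antiproliferative activity, read by MTT assay, with a stated time of 72 h; on this read-out higher numbers stand for weaker inhibition and lower numbers for stronger inhibition. Compound 1 `CC1=CCC2C(CC[C@@]2(C)O)C(C)(C)C1CC[C@@H]1[C@@]2(C)CC[C@@H](O)C(C)(C)O[C@@H]2CC[C@]1(C)O`, which carries a free hydroxyl on the shared core, reads > 50000 nM. That reading is a limit of the assay and not a number. Among the measured compounds shown here, compound 2 `CC1=CC[C@H]2[C@H](CC[C@]2(C)O)C(C)(C)[C@@H]1CC[C@H]1[C@]2(C)CC[C@H](OC(=O)CCC(=O)O)C(C)(C)O[C@H]2CC[C@@]1(C)O`, an ester on the same core, gives 27900 nM, the only true number available in this assay. Compound 2 therefore stands as the sole measured reference point for what follows.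

Compound 3 `CC1=CC[C@H]2[C@H](CC[C@]2(C)O)C(C)(C)[C@@H]1CC[C@H]1[C@]2(C)CC[C@H](OC(=O)NS(=O)(=O)c3ccc(C)cc3)C(C)(C)O[C@H]2CC[C@@]1(C)O` keeps the shared core and the carbonyl carbon, but ((4-methylphenyl)sulfonyl)amino stands in place of 2-carboxyethyl: ((4-methylphenyl)sulfonyl)amino in place of 2-carboxyethyl on a carbonyl carbon. For the measured compounds named here, no measured pair shows what such an exchange does, so the expectation rests on compound 2 at 27900 nM alone. No shift beyond the usual scatter is expected, and the estimated change is a 1.4-fold lower number from compound 2 to compound 3 (0.14 log units; within the scatter). A reading that again ends at the limit of the assay cannot be ruled out. For compound 3 the estimated value is 20000 nM, with an expected range of 7000 nM to 50000 nM.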

Compound 3, half-maximal inhibitory concentration: 47100 nM
The estimate for compound 3 lay 2.4-fold (0.37 log units) below the measured number, and the stated range covers the measured number.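

In this assay, ((4-methylphenyl)sulfonyl)amino in place of 2-carboxyethyl on a carbonyl carbon gives a 1.7-fold higher number from compound 2 to compound 3 (0.23 log units; within the scatter), so no order can be set between the two compounds. This position therefore carries a group with a six-membered aromatic ring and more heavy atoms than 2-carboxyethyl, with no step beyond the scatter. The carboxylic acid of compound 2 is also absent from compound 3, and this pair shows that a true number is still obtained without it, while compound 1 alone stays at a limit and not a number: the limit of > 50000 nM in this assay, at which 1 of the 3 values shown sits.

The compounds shown leave open whether an amine, a longer carboxylic acid chain or a simple acetyl ester on this carbonyl carbon would move the number beyond the scatter. They also leave open whether the methyl on the aromatic ring of compound 3 matters, since a plain phenyl or a chloro-substituted phenyl sulfonyl group does not stand among them.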